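The source may report more compounds than this note shows. Statements on the series, on what has been measured and on what is new or still open speak of the compounds shown alone.

Measured so far:
compound 1 `Cc1ccc(Nc2cc(C)nc(SCc3nc4ccccc4[nH]3)n2)cc1` — in a functional assay on MCF7 cells (Homo sapiens) for cytotoxicity, read by MTT assay, with a stated time of 72 h (a higher number here means a weaker inhibitor, a lower number a stronger inhibitor), compound 1 gives 56500 nM
compound 2 `Cc1cc(Nc2ccc(F)cc2)nc(SCc2nc3ccccc3[nH]2)n1` — in this assay compound 2 gives 42200 nM

For the measured compounds named here, compound 2 holds the lowest of the two numbers; its only neighbour is compound 1, and the step of a 1.3-fold lower number from compound 1 to compound 2 (0.13 log units; within the scatter) lies within the scatter, so the two stand together rather than in order.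

Compound 3 `Cc1cc(NNC(N)=S)nc(SCc2nc3ccccc3[nH]2)n1` has not yet been measured. It differs from compound 2 by a group of 4 heavy atoms (1 carbon, 2 nitrogen, 1 sulfur; no ring) in place of a group of 7 heavy atoms (6 carbon, 1 fluorine; one six-membered aromatic ring of carbon only), on a nitrogen on an aromatic ring.

Going by the values given here, the one measured step, fluoro in place of methyl on an aromatic carbon, is small and leaves the aromatic ring in place; it says nothing about exchanging that ring for the entering group of 4 heavy atoms. Among the compounds with values here, no measured step bears on this change, so no direction is claimed for this assay. In the absence of any guiding step, compound 3 is expected to sit near compound 2, with a 1.2-fold higher number from compound 2 to compound 3 (0.07 log units; within the scatter) carrying wide uncertainty. Compound 3 is thus estimated at 50000 nM, with a range from 12000 nM to 200000 nM.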

Compound 3, half-maximal inhibitory concentration: > 100000 nM
Compound 3 gave a limit, no number; the forecaster's own chance of this, stated with the estimate: 20%; middle value at least 2.0-fold (0.30 log units) from the limit.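

Compound 3 in this assay gives > 100000 nM, which is a limit of the assay and not a number: the limit of > 100000 nM in this assay, at which 1 of the 3 values shown sits.

For the compounds shown here, at this place, on a nitrogen on an aromatic ring, the first large change separates two compounds: exchanging 4-fluorophenyl for the group of 4 heavy atoms gives an at least 2.3-fold higher number from compound 2 to compound 3 (0.37 log units; beyond the scatter). The same kind of exchange starting from the methyl-bearing aromatic ring gives an at least 1.7-fold higher number from compound 1 to compound 3 (0.24 log units; that floor lies within the scatter), so this comparison alone sets no order.

The compounds shown leave open whether the step follows the loss of the aromatic ring or the arrival of the entering group. A plain amine, a phenyl without substituent or a pyridine ring at this place would help separate the two.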